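Swapping Chloro for Fluoro on a Bithiophene Amidine

The compounds below may be only part of what the source reports. "The series", "measured", "known", "first", "only" and "open" are said of these compounds alone.

Compound 1 `N=C(N)c1ccc(-c2ccc(-c3ccc(Cl)cc3)s2)s1` was tested in a functional assay on HOP-62 cells (Homo sapiens) for inhibition, read by sulforhodamine B assay, with a stated time of 48 h (on this read-out higher numbers stand for weaker inhibition of growth and lower numbers for stronger inhibition of growth), and gave 1750 nM. Among the three measured compounds this is the second-highest number. Compound 2 `N=C(N)c1ccc(-c2ccc(-c3cncc4ccccc34)s2)s1` gives 1700 nM, a value within the scatter of compound 1, so the two cannot be told apart. Compound 3 `N=C(N)c1ccc(-c2ccc(-c3ccccc3)o2)o1` gives 3590 nM, a number beyond the scatter higher than that of compound 1, meaning weaker inhibition of growth.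

Compound 4 `N=C(N)c1ccc(-c2ccc(-c3ccc(F)cc3)s2)s1` has not yet been measured. It differs from compound 1 in one place: fluoro in place of chloro on an aromatic carbon. Within the data shown here, no measured pair shows this kind of exchange, so there is no step to lean on. The change is small, and the expected step from compound 1 to compound 4 is a 1.1-fold higher number from compound 1 to compound 4 (0.06 log units; within the scatter), that is, none beyond the scatter. Compound 4 is therefore estimated at 2000 nM, with a range from 900 nM to 4500 nM.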

Compound 4, concentration for 50% growth inhibition: 1640 nM
Beside the measured number, compound 4's estimate is 1.2-fold (0.09 log units) above it; the measured number falls inside the stated range.
By their numbers in this assay, from the lowest: compounds 4, 2 and 1 (each within the scatter of the next); then compound 3.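

Among these compounds, on the aromatic carbon para to a large group, fluoro in place of chloro gives a 1.1-fold lower number from compound 1 to compound 4 (0.03 log units; within the scatter) in this assay and so offers the first direct reading of a change at this position. Across this single exchange, compound 1 and compound 4 cannot be told apart, so this position accepts either of these two single-atom groups without a change beyond the scatter.

From the compounds shown here alone, whether an amine, a carboxylic acid or a longer chain at the same place would also keep the number within the scatter stays open. Nothing available explains why chloro and fluoro match here.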